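A few compounds are considered here, and "the series" means these few. Any claim that something is new, unique, unknown or untested is made for them only; others in the source may bear on it.

Working notes on the series in a functional assay on MGC-803 cells (Homo sapiens) for cytotoxicity, read by MTT assay, with a stated time of 72 h; on this read-out higher numbers stand for weaker inhibition and lower numbers for stronger inhibition.

Three compounds share one core. Compound 1 `FC(F)(F)c1ccc(CSc2nc(Nc3ccccc3C(F)(F)F)c3ccccc3n2)cc1` carries a 2-(trifluoromethyl)phenyl on the ring nitrogen, compound 2 `FC(F)(F)c1ccc(CSc2nc(Nc3ccccc3Cl)c3ccccc3n2)cc1` a 2-chlorophenyl, and compound 3 `CCOc1ccccc1Nc1nc(SCc2ccc(C(F)(F)F)cc2)nc2ccccc12` a 2-ethoxyphenyl. In this assay compound 1 gives only a limit, > 50000 nM. Compound 2 likewise gives only a limit, > 50000 nM. Compound 3 also reaches no number, its value standing as the limit > 50000 nM. All three sit at the limit of > 50000 nM in this assay, at which 3 of the 3 values shown sit, so the steps a step that the two limits leave unreadable from compound 1 to compound 2, a step that the two limits leave unreadable from compound 1 to compound 3 and a step that the two limits leave unreadable from compound 2 to compound 3 cannot be sized.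

Compound 4 `FC(F)(F)c1ccc(CSc2nc(Nc3cccc(Cl)c3)c3ccccc3n2)cc1` is not yet measured. Against compound 3 the change is 3-chlorophenyl in place of 2-ethoxyphenyl on a nitrogen on an aromatic ring. Within the data shown here, none of the measured steps gives a readable size for any swap on this nitrogen, so no direction can be drawn from them; the only information is that every measured compound sits at the limit. The expected step is a step that the limit leaves unreadable from compound 3 to compound 4, which is nothing beyond the scatter. Compound 4 is therefore expected to give about 60000 nM, with a range from 20000 nM to 200000 nM, most likely again reported only as a limit.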

Compound 4, half-maximal inhibitory concentration: 14600 nM
Estimate against measurement, compound 4: 4.1-fold (0.61 log units) above; measured number below the stated range.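

In this assay this nitrogen gives its first readable steps, and the clearest is between two chlorinated groups: 3-chlorophenyl in place of 2-chlorophenyl gives an at least 3.4-fold lower number from compound 2 to compound 4 (0.53 log units; beyond the scatter). The other two swaps read alike, with 3-chlorophenyl in place of 2-ethoxyphenyl giving an at least 3.4-fold lower number from compound 3 to compound 4 (0.53 log units; beyond the scatter) and in place of 2-(trifluoromethyl)phenyl giving an at least 3.4-fold lower number from compound 1 to compound 4 (0.53 log units; beyond the scatter). Each size is only a bound, set by the limit shared by compound 1, compound 2 and compound 3: the limit of > 50000 nM in this assay, at which 3 of the 4 values shown sit.

From the compounds shown here alone, the steps among those three compounds cannot be read, so their order remains unknown, and one compound with a number cannot show how far the result depends on chlorine or on where it sits. Going by these compounds, whether a 3-aminophenyl or a 3-carboxyphenyl on this nitrogen would reach a number also stays open.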